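The source may report more compounds than this note shows. Statements on the series, on what has been measured and on what is new or still open speak of the compounds shown alone.

Measured so far:
compound 1 `CC(C)c1ccc(NC2=NCCC3(CCCCC3)S2)cc1` — 1.57
compound 2 `O=C(NC1=NCCC2(CCCCC2)S1)c1ccccc1` — 1.55

In a physicochemical assay for lipophilicity, measured as octanol-water partition, at pH 7.4 (on this read-out lower numbers stand for lower lipophilicity and higher numbers for higher lipophilicity), compound 1 gives 1.57, the highest of the two numbers; in this assay compound 2 gives 1.55, which lies within the scatter of compound 1, so the two are not separated. Among the compounds with values here, no pair of measured compounds differs in a single place, so no measured step is available.

Compound 3 `Cc1ccc(NC2=NCCC3(CCCCC3)S2)cc1` is not yet measured. It differs from compound 1 as follows: methyl in place of isopropyl on an aromatic carbon. Within the data shown here, no measured pair shows this change, so the expectation rests on the structures alone. The step from compound 1 to compound 3 is expected to be a fall beyond the scatter, of size a number 0.87 log units lower from compound 1 to compound 3 (beyond the scatter). For compound 3 the estimated value in this assay is 0.7, with a range from 0.3 to 1.1.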

Compound 3, distribution coefficient: 1.56
Beside the measured number, compound 3's estimate is 0.86 log units below it; the measured number lies above the stated range.
By their numbers in this assay, from the lowest: compounds 2, 3 and 1 (each within the scatter of the next).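

In this assay, within the data shown here, methyl in place of isopropyl on an aromatic carbon, para to a large group, is the only single-place change available, and it reads a number 0.01 log units lower from compound 1 to compound 3 (within the scatter). Among these compounds, compound 1 and compound 3 are therefore not separated on this read-out, so at this position the exchange of these two groups has no measurable result, something the earlier compounds could not show. No supporting evidence is available to account for this result.

Going by these compounds, only isopropyl and methyl have been compared at this position, so it remains open whether a longer chain, an amine or a carboxylic acid in the same place would separate from compound 1 in this assay. On these data alone, it is also open whether the same exchange would read alike on a core other than that of compound 1.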